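The source may hold more compounds than are shown below. What is called first, only, known or untested is meant among the compounds shown, and "the series" means these compounds.

In a functional assay on SMMC-7721 cells (Homo sapiens) for antiproliferative activity, read by CCK-8 assay, with a stated time of 72 h (on this read-out higher numbers stand for weaker inhibition and lower numbers for stronger inhibition), compound 1 (`Nc1ccccc1NC(=O)c1ccc(CSC(=S)N2CCc3cc(Cl)ccc32)cc1`) gives 1880 nM and compound 2 (`CC1CCCCN1C(=S)SCc1ccc(C(=O)Nc2ccccc2N)cc1`) gives 2950 nM as its reading. Among the measured compounds shown here, compound 2 therefore stands within the scatter of compound 1, the only other measured compound. Compound 3 (`CCN(Cc1ccncc1)C(=S)SCc1ccc(C(=O)Nc2ccccc2N)cc1`) differs from compound 2 on the thiocarbonyl carbon (ethyl((pyridin-4-yl)methyl)amino in place of 2-methylpiperidin-1-yl on a thiocarbonyl carbon), with ethyl((pyridin-4-yl)methyl)amino in place of 2-methylpiperidin-1-yl. For the measured compounds named here, the one measured step at that carbon (a 1.6-fold higher number from compound 1 to compound 2 (0.20 log units; within the scatter)) lies within the scatter, and no measured compound carries the entering group. In this assay, going by the values given here, compound 2 gives 2950 nM, and that single step is the only guide, so compound 3 is expected to stay within the scatter of that reading. The estimated step (a 1.1-fold lower number from compound 2 to compound 3 (0.02 log units; within the scatter)) is accordingly small. For compound 3 the estimate is 2800 nM with an expected range from 1000 nM to 7500 nM and is kept wide, resting on one step only.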

Compound 3, half-maximal inhibitory concentration: 1210 nM
Compound 3: the middle estimate sits 2.3-fold (0.36 log units) above what was measured; low and high end bracket the measured number.
By their numbers in this assay, from the lowest: compounds 3, 1 and 2 (each within the scatter of the next, the first and the last beyond it).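

In this assay, the thiocarbonyl carbon now gives a step beyond the scatter: ethyl((pyridin-4-yl)methyl)amino in place of 2-methylpiperidin-1-yl gives a 2.4-fold lower number from compound 2 to compound 3 (0.39 log units; beyond the scatter), a modest change, whereas the earlier step at this carbon stayed within the scatter. The same entering group in place of 5-chloro-2,3-dihydro-1H-indol-1-yl gives a 1.6-fold lower number from compound 1 to compound 3 (0.19 log units; within the scatter), so compound 1 and compound 3 cannot be told apart here. No supporting data are available to explain the step from 2-methylpiperidin-1-yl to ethyl((pyridin-4-yl)methyl)amino.

From the compounds shown here alone, it remains open whether the ring nitrogen of the pyridine matters, a question that an ethyl(benzyl)amino group, with a phenyl ring in its place, would address. Going by these compounds, the role of the ethyl chain is also open, and methyl or propyl on the same nitrogen would test it.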